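The compounds below may be only part of what the source reports. "The series", "measured", "known", "first", "only" and "open" are said of these compounds alone.

Working notes on the series. In a functional assay on V79 cells (Cricetulus griseus) for cytotoxicity, read by colony formation (a lower number here means a stronger inhibitor, a higher number a weaker inhibitor), compound 1 `O=C(O)c1cn(C2CC2)c2c(F)c(N3CCCC3)c(F)cc2c1=O` gives 120 ug/mL. In this assay compound 2 `O=C(O)c1cn(C2CC2)c2c(C(F)(F)F)c(N3CCCC3)c(F)cc2c1=O` gives 280 ug/mL. Compound 2 and compound 1 differ by fluoro in place of trifluoromethyl on an aromatic carbon, and that change gives a 2.3-fold lower number from compound 2 to compound 1 (0.37 log units; beyond the scatter). In this assay compound 3 `Cc1c(F)c(N2CCC(N)C2)c(C(F)(F)F)c2c1c(=O)c(C(=O)O)cn2C1CC1` gives 290 ug/mL, a number within the scatter of that of compound 2; the difference between the core of compound 3 and the core of compound 2 is not broken down here. Compound 4 `Cc1c(F)c(N2CCC(N)C2)c(F)c2c1c(=O)c(C(=O)O)cn2C1CC1` has not been measured in this assay. It differs from compound 3 by fluoro in place of trifluoromethyl on an aromatic carbon. Among the compounds with values here, this is the same kind of change as the one from compound 2 to compound 1, not the same: in compound 3 the place is ortho to a 3-aminopyrrolidin-1-yl group and para to a methyl group, whereas in compound 2 the place is ortho to a pyrrolidin-1-yl group and no methyl group is counted around it. Within the data shown here, only one measured instance of this change exists, so the expectation for compound 4 rests on it alone. Among the measured compounds shown here, the only measured guide for this change is a 2.3-fold lower number from compound 2 to compound 1 (0.37 log units; beyond the scatter). Taking that step as the guide, a step of about a 2.2-fold lower number from compound 3 to compound 4 (0.35 log units; beyond the scatter) is expected, with wider bounds since the surroundings of the place differ. The estimate for compound 4 in this assay is 130 ug/mL, expected to lie between 70 ug/mL and 260 ug/mL.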

Compound 4, half-maximal inhibitory concentration: 11 ug/mL
For compound 4 the middle estimate is 12-fold (1.07 log units) above the measured one; the measured number lies below the stated range.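

In this assay, fluoro in place of trifluoromethyl on an aromatic carbon gives a 26-fold lower number from compound 3 to compound 4 (1.42 log units; beyond the scatter), and this step does not match the earlier one in size, so the size of the step does not carry from one core to the other: the same change on two cores in this assay, a 2.3-fold lower number (0.37 log units; beyond the scatter) from compound 2 to compound 1 and a 26-fold lower number (1.42 log units; beyond the scatter) from compound 3 to compound 4, 11-fold (1.05 log units) apart, beyond the scatter of two such steps
What does carry across these two pairs is the direction, with the fluoro compound giving the lower number on both cores, though two pairs are too few to make this a rule for the series. The pairs do not show which difference between them goes with the gap, since the place in compound 3 is ortho to a 3-aminopyrrolidin-1-yl group and para to a methyl group, whereas in compound 2 it is ortho to a pyrrolidin-1-yl group and no methyl group is counted around it.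

The compounds shown leave open whether the amine on the pyrrolidine ring, the methyl group or the two together go with the larger step. They also leave open how a chloro group or a nitrile on the same aromatic carbon would stand against fluoro and trifluoromethyl in this assay.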